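Replacing sulfamoyl on a pyridin-4-yl pyrimidine amine

This account rests on a few compounds, and the source may have more. Where it says the series, first, only, none or still open, it means among the compounds named here.

Measured compounds:
compound 1 `Cc1cc(-c2ccccn2)nc(Nc2ccc(N(C)C)cc2)n1` gives 31900 nM
compound 2 `NS(=O)(=O)c1ccc(Nc2nccc(-c3cccnc3)n2)cc1` gives 200 nM
compound 3 `NS(=O)(=O)c1ccc(Nc2nccc(-c3ccncc3)n2)cc1` gives 5100 nM

In a functional assay for inhibition, with Homo sapiens as the target (on this read-out lower numbers stand for stronger inhibition and higher numbers for weaker inhibition), compound 3 holds the second highest of the three numbers; compound 2 sits well below it, and compound 1 well above it. Among the compounds with values here, the only single-point step among the measured compounds is a 26-fold higher number from compound 2 to compound 3 (1.41 log units; beyond the scatter), which concerns the pyridyl ring and not the group on the aniline ring. Compound 4 `CCN(CC)CCCOc1ccc(Nc2nccc(-c3ccncc3)n2)cc1` differs from compound 3 in this way: 3-(diethylamino)propoxy in place of sulfamoyl on an aromatic carbon. Within the data shown here, no measured step touches this position. Compound 1 carries a different group on that ring but also a different core, so its value next to that of compound 3 cannot be read as a step. Since nothing measured bears directly on the change, compound 4 is expected to land near compound 3, with a wide range, and the step of a 1.6-fold higher number from compound 3 to compound 4 (0.20 log units; within the scatter) is an estimate of no clear direction. Compound 4 is therefore estimated at 8000 nM, between 1500 nM and 40000 nM.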

Compound 4, half-maximal inhibitory concentration: 1300 nM
For compound 4 the middle estimate is 6.2-fold (0.79 log units) above the measured one, and the stated range ends above it.
By their numbers in this assay, from the lowest: compound 2; then compound 4; then compound 3; then compound 1.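

In this assay, within the data shown here, the change at this position gives a 3.9-fold lower number from compound 3 to compound 4 (0.59 log units; beyond the scatter) and so is the first measured step on the aniline ring, where the earlier step concerned only the pyridyl ring. On this core, sulfamoyl is therefore not needed for a number in this range, since 3-(diethylamino)propoxy, with its longer chain and no hydrogen-bond donor, gives a lower number. No measurement shown here explains this step.

The compounds shown do not separate the contribution of the diethylamino group from that of the propoxy chain, so a shorter chain, a morpholine in place of the diethylamine or a simple methoxy group would be informative at this place. Going by these compounds, it also remains open whether 3-(diethylamino)propoxy would lower the number to a similar extent with the pyridin-3-yl ring of compound 2.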